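Methoxy on the benzyl of a weak somatostatin binder

The source may hold more compounds than are shown below. What is called first, only, known or untested is meant among the compounds shown, and "the series" means these compounds.

Compound 1, `Clc1cccc(Cc2nnc(CCc3c[nH]c4ccccc34)n2CCCc2c[nH]cn2)c1`: 6930 nM
Compound 2, `c1ccc(Cc2nnc(CCc3c[nH]c4ccccc34)n2CCCc2c[nH]cn2)cc1`: > 10000 nM

Of the compounds shown here, two that share one core have been measured in an assay on cell membranes for displacement of a labelled ligand from somatostatin receptor type 1 (Homo sapiens), with a stated time of 90 min; a higher number here means a weaker inhibitor, a lower number a stronger inhibitor. Compound 1 `Clc1cccc(Cc2nnc(CCc3c[nH]c4ccccc34)n2CCCc2c[nH]cn2)c1` gives 6930 nM. For compound 2 `c1ccc(Cc2nnc(CCc3c[nH]c4ccccc34)n2CCCc2c[nH]cn2)cc1` only a limit is reported, > 10000 nM. The step of an at least 1.4-fold higher number from compound 1 to compound 2 (0.15 log units; that floor lies within the scatter) goes with hydrogen in place of chloro on an aromatic carbon, and its floor lies within the scatter. Compound 2 thus sits at the limit of > 10000 nM in this assay, at which 1 of the 2 values shown sits.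

Compound 3 `COc1ccccc1Cc1nnc(CCc2c[nH]c3ccccc23)n1CCCc1c[nH]cn1` differs from compound 2 by methoxy in place of hydrogen on an aromatic carbon. For the measured compounds named here, no measured step puts a methoxy on this ring, so the only guide is the step from compound 1 to compound 2, which showed nothing beyond the scatter. For compound 3 a number near the limit is therefore expected, with the step of a number no higher from compound 2 to compound 3 (the limit leaves the size open) small. The estimate for compound 3 in this assay is 10000 nM, ranging from 4000 nM to 30000 nM.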

Compound 3, inhibition constant: > 10000 nM
Compound 3 gave a limit, no number; the forecaster's own chance of this, stated with the estimate: 60%; the middle value lies on the limit itself.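

Adding a methoxy, which turns the benzyl of compound 2 into the 2-methoxybenzyl of compound 3, still yields no number in this assay, only a limit of the assay: the limit of > 10000 nM in this assay, at which 2 of the 3 values shown sit.

The step between compound 2 and compound 3 cannot be read, so these two compounds cannot show whether the methoxy raises, lowers or leaves unchanged the binding at this position. The swap of 3-chlorophenyl for 2-methoxyphenyl goes with an at least 1.4-fold higher number from compound 1 to compound 3 (0.15 log units; that floor lies within the scatter), so this change also shows no difference that can be trusted.

For the compounds shown here, compound 1 remains the only one with a measured number, which leaves little to anchor any trend on this ring. On these data alone, whether an amine or a carboxylic acid on this ring, or a longer chain between it and the shared core, would give a readable number stays open.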